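A few compounds are considered here, and "the series" means these few. Any claim that something is new, unique, unknown or untested is made for them only; others in the source may bear on it.

Compound 2 `CN(CCO)N(c1cc(C#CC(C)(C)C)sc1C(=O)O)C(=O)[C@H]1CC[C@H](C)CC1` stands at a limit in an ADME assay on Huh-7 cells (Homo sapiens) for cytotoxicity, read by fluorescence, with a stated time of 3 days; a higher number here means that more compound is tolerated, a lower number that less compound is tolerated: compound 2 gives > 44000 nM, which is a limit of the assay rather than a number (the limit of > 44000 nM in this assay, at which 1 of the 2 values shown sits). In this assay compound 1 `CN(c1ccncc1)N(c1cc(C#CC(C)(C)C)sc1C(=O)O)C(=O)[C@H]1CC[C@H](C)CC1` gives 36000 nM. For the measured compounds named here, the only measured step, an at least 1.2-fold higher number from compound 1 to compound 2 (0.08 log units; that floor lies within the scatter), alters the same amine nitrogen substituent and is within the scatter. Compound 3 `CN(CC1CCOCC1)N(c1cc(C#CC(C)(C)C)sc1C(=O)O)C(=O)[C@H]1CC[C@H](C)CC1` differs from compound 2 by oxan-4-yl in place of hydroxymethyl on a saturated chain carbon bound to an amine nitrogen. With that single step as a guide, compound 3 is expected to show no step beyond the scatter, an at least 1.1-fold lower number from compound 2 to compound 3 (0.04 log units; that floor lies within the scatter). Compound 3 is therefore estimated at 40000 nM, with a range from 15000 nM to 90000 nM.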

Compound 3, half-maximal cytotoxic concentration: > 44000 nM
Compound 3 was reported as a limit; the forecaster's own chance of this, stated with the estimate: 55%; middle value at least 1.1-fold (0.04 log units) from the limit.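

In this assay compound 3 gives > 44000 nM, which is a limit of the assay and not a number. The step from compound 2 to compound 3 cannot be read because both sit at this limit: the limit of > 44000 nM in this assay, at which 2 of the 3 values shown sit. Still, (oxan-4-yl)methyl in place of pyridin-4-yl on the amine nitrogen gives an at least 1.2-fold higher number from compound 1 to compound 3 (0.08 log units; that floor lies within the scatter), so the chain stays at the limit with a six-membered non-aromatic ring and without the hydroxyl group of compound 2. From the compounds shown here alone, whether an amine or a carboxylic acid on this saturated chain carbon would give a readable number stays open.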